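Working notes on the step from compound 2 to compound 3

A few compounds are considered here, and "the series" means these few. Any claim that something is new, unique, unknown or untested is made for them only; others in the source may bear on it.

Compound 1 `C[C@H](Nc1cc(=O)oc2cc(OCc3ccccc3)ccc12)C(N)=O` in an assay (strain Wistar) for inhibition of Amine oxidase [flavin-containing] A (Rattus norvegicus) (a lower number here means a stronger inhibitor, a higher number a weaker inhibitor), gives 100000 nM. Compound 2 `NC(=O)[C@H](CO)Nc1cc(=O)oc2cc(OCc3cccc(Cl)c3)ccc12` gives only a limit of this assay, > 100000 nM. Compound 2 thus stands at the limit of > 100000 nM in this assay, at which 1 of the 2 values shown sits. Compound 3 `NNC(=O)Cc1cc(=O)oc2cc(OCc3cccc(Cl)c3)ccc12` carries (aminocarbamoyl)methyl in place of (1-carbamoyl-2-hydroxyethyl)amino on an aromatic carbon, that is, (aminocarbamoyl)methyl in place of (1-carbamoyl-2-hydroxyethyl)amino on an aromatic carbon. Going by the values given here, no step between measured compounds covers this change, so no measured size is at hand. The step of an at least 1.6-fold lower number from compound 2 to compound 3 (0.22 log units; that floor lies within the scatter) is expected to stay small, at most a modest gain not clearly beyond the scatter. Compound 3 is estimated at 60000 nM in this assay, within 8000 nM to 100000 nM.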

Compound 3, half-maximal inhibitory concentration: 2500 nM
Compound 3: middle estimate off by 24-fold (1.38 log units), on the high side; measured number outside the range, below it.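

Putting (aminocarbamoyl)methyl in place of (1-carbamoyl-2-hydroxyethyl)amino opposite the ring oxygen gives an at least 40-fold lower number from compound 2 to compound 3 (1.60 log units; beyond the scatter) in this assay. This position is therefore not indifferent to its substituent, which compounds 1 and 2 alone could not show. The size of the step is only a floor, and compound 2 gives a limit, not a number: the limit of > 100000 nM in this assay, at which 1 of the 3 values shown sits.

The step changes both the link to the ring and the end of the chain, and these two changes cannot be separated here. From the compounds shown here alone, how a carboxylic acid or a longer chain ending in the same aminocarbamoyl group would read at this position stays open.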